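The source may report more compounds than this note shows. Statements on the series, on what has been measured and on what is new or still open speak of the compounds shown alone.

Measured compounds: compound 1 `O=C(NCc1ccc(S(=O)(=O)c2cc(F)cc(F)c2)cc1)c1cc2ccncc2o1` with 77%, compound 2 `O=C(NCc1ccc(S(=O)(=O)c2cccc(C(F)(F)F)c2)cc1)c1cnc2nccn2c1` with 41%, compound 3 `O=C(NCc1ccc(S(=O)(=O)c2ccccc2)cc1)c1cnc2nccn2c1` with 60%, all in an ADME assay on microsomes from liver (Homo sapiens) for metabolic stability, read by LC-MS, with a stated time of 30 min, tested at 1 uM; on this read-out higher numbers stand for a more stable compound and lower numbers for a less stable compound.

Compound 2 stands lowest of the three numbers; compound 3 is nearest and compound 1 furthest above it. Compound 4 `O=C(NCc1ccc(S(=O)(=O)c2cccc(C(F)(F)F)c2)cc1)c1cc2ccncc2o1` differs from compound 2 by a group of 9 heavy atoms (7 carbon, 1 nitrogen, 1 oxygen; one five-membered aromatic ring with 1 hetero atom, one six-membered aromatic ring with 1 hetero atom) in place of a group of 9 heavy atoms (6 carbon, 3 nitrogen; one five-membered aromatic ring with 2 hetero atoms, one six-membered aromatic ring with 2 hetero atoms), on a carbonyl carbon. Within the data shown here, no measured step isolates this exchange: the only measured step, a number 19 percentage points higher from compound 2 to compound 3 (beyond the scatter), concerns the trifluoromethyl, which compound 4 keeps. Compound 1, which carries the same group on the carbonyl carbon as compound 4 but differs at the sulfonyl aryl as well, shows the highest number. An upward step is therefore expected, with wide uncertainty, as a number 14 percentage points higher from compound 2 to compound 4 (beyond the scatter). Compound 4 is estimated at 55%, between 35% and 75%.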

Compound 4, percent of the compound remaining: 48%
The estimate for compound 4 lay 7 percentage points above the measured number; measured number inside the range.
By their numbers in this assay, from the lowest: compounds 2 and 4 (each within the scatter of the next); then compound 3; then compound 1.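

With trifluoromethyl kept, the exchange on the carbonyl carbon gives a number 7 percentage points higher from compound 2 to compound 4 (within the scatter) in this assay, so this position tolerates the change of group without a step beyond the scatter in this pair. Among these compounds, by contrast, 3-(trifluoromethyl)phenyl in place of 3,5-difluorophenyl on the sulfonyl sulfur gives a number 29 percentage points lower from compound 1 to compound 4 (beyond the scatter), so among the new steps only the one at the sulfonyl sulfur lies beyond the scatter.

From the compounds shown here alone, whether the carbonyl exchange reads the same with 3,5-difluorophenyl on the sulfonyl sulfur stays open, as does the outcome for an amine or a carboxylic acid on the carbonyl carbon. Nothing shown here gives a cause for either step.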